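A few compounds are considered here, and "the series" means these few. Any claim that something is new, unique, unknown or untested is made for them only; others in the source may bear on it.

Measured so far in a physicochemical assay for lipophilicity, read by HPLC, at pH 7.4 (on this read-out lower numbers stand for lower lipophilicity and higher numbers for higher lipophilicity), are these compounds:
- compound 1 `COCCOc1cc2oc(=O)n(CCC(=O)O)c2cc1Cl` at 0.88
- compound 2 `Cc1ccc([C@@H](C)Oc2cc3onc(CCC(=O)O)c3cc2Cl)nc1` at 2.42
- compound 3 `O=C(O)CCn1c(=O)oc2cc(OCC3CCC3)c(Cl)cc21` at 2.9

Of these three, compound 2 holds the middle place, with compound 3 higher and compound 1 lower, and both gaps lie beyond the scatter. Compound 4 `C[C@@H](Oc1cc2onc(CCC(=O)O)c2cc1Cl)c1ccc(Cl)cn1` has not been measured yet. It differs from compound 2 in one place chloro in place of methyl on an aromatic carbon and the swap is chloro in place of methyl on an aromatic carbon, turning 5-methylpyridin-2-yl into 5-chloropyridin-2-yl.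

Within the data shown here, only one measured step compares two compounds that differ in one place. That step is a number 2.02 log units higher from compound 1 to compound 3 (beyond the scatter) and it is large, but it is a different swap, cyclobutyl in place of methoxymethyl, so it is at best a loose guide. Among the measured compounds shown here, no measured step covers the swap of methyl for chloro. Here one heavy atom replaces one heavy atom, so starting from compound 2 at 2.42 only a small upward move is expected in this assay and it may well stay within the scatter. The estimated step is a number 0.18 log units higher from compound 2 to compound 4 (within the scatter) and no large jump is expected. Compound 4 is expected at 2.6 with an estimated range from 2.2 to 3 once it is measured.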

Compound 4, distribution coefficient: 2.91
Compound 4: middle estimate off by 0.31 log units, on the low side; low and high end bracket the measured number.
By their numbers in this assay, from the lowest: compound 1; then compound 2; then compounds 3 and 4 (each within the scatter of the next).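

In this assay, turning 5-methylpyridin-2-yl into 5-chloropyridin-2-yl gives a number 0.49 log units higher from compound 2 to compound 4 (beyond the scatter) and so moves the read-out by a modest amount. This shows that a change of a single heavy atom on this aromatic carbon can register beyond the usual scatter, even though no ring, hydrogen-bond donor, hydrogen-bond acceptor or net charge enters or leaves. Among these compounds, the only earlier step involved a different swap at a different place, so it could not show this, and nothing measured here explains the direction of the change.

From the compounds shown here alone, it remains open how other groups at this position, such as fluoro, methoxy, nitrile or an amine, would compare with methyl and chloro. Going by these compounds, it is also open whether the same swap would give a similar step on a different core.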